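Methoxy to isopropoxy on the core of compound 3

The source may report more compounds than this note shows. Statements on the series, on what has been measured and on what is new or still open speak of the compounds shown alone.

In a functional assay on A549 cells (Homo sapiens) for antiproliferative activity, read by sulforhodamine B assay, with a stated time of 72 h (a higher number here means a weaker inhibitor of growth, a lower number a stronger inhibitor of growth), compound 3, with the structure `CCc1cc(=O)c2ccc(OC)c(CBr)c2o1`, gives > 33600 nM, which is a limit of this assay rather than a number. Compound 1, `Cc1cc(=O)oc2cc(SCc3ccncc3)ccc12`, gives > 35200 nM, also a limit. Compound 2, `Cc1cc(=O)oc2cc(SCc3cccc(C(F)(F)F)c3)ccc12`, gives > 28500 nM, again a limit. Among the compounds with values here, all three values therefore sit at limits, and no step between them can be sized. Compound 4, `CCc1cc(=O)c2ccc(OC(C)C)c(CBr)c2o1`, differs from compound 3 by one change: isopropyl in place of methyl on an oxygen on an aromatic ring. Within the data shown here, with no measured step to draw on, the step from compound 3 to compound 4 in this assay is expected to be a step that the limit leaves unreadable from compound 3 to compound 4, that is, nothing beyond the scatter in either direction. Compound 4 is estimated at 40000 nM, within 15000 nM to 120000 nM, most likely reported as a limit.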

Compound 4, concentration for 50% growth inhibition: > 30700 nM
Compound 4 was reported as a limit (the forecaster's own chance of this, stated with the estimate: 80%); the middle value does not contradict the limit.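

Compound 3 and compound 4 are both reported as limits, so the step from methoxy to isopropoxy cannot be read. The compounds shown leave open whether any change on these cores yields a measurable growth inhibition value.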